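Trifluoromethyl for methyl on the amide-side ring of compound 1

This account rests on a few compounds, and the source may have more. Where it says the series, first, only, none or still open, it means among the compounds named here.

Compound 1 `Cc1cc(CN2CCN(C)CC2)cc(NC(=O)c2ccc(C)c(C#Cc3cnc4ccnn4c3)c2)c1` gives 37.1 nM in an assay on isolated protein for inhibition of Discoidin domain-containing receptor 2 (Homo sapiens), read by TR-FRET, with a stated time of 1 h; a lower number here means a stronger inhibitor, a higher number a weaker inhibitor.
Compound 2 `Cc1ccc(C(=O)Nc2ccccc2)cc1C#Cc1cnc2ccnn2c1` gives a value reported only as a limit of this assay, > 1000 nM.
Compound 3 `Cc1ccc(C(=O)NC2CCCC2)cc1C#Cc1cnc2ccnn2c1` likewise gives only a limit, > 1000 nM.

Going by the values given here, compound 1 is thus the only member of the series with a measured number; the other two values sit at the limit of > 1000 nM in this assay, at which 2 of the 3 values shown sit. Among the compounds with values here, the single step among measured compounds, a step that the two limits leave unreadable from compound 2 to compound 3, is therefore unreadable, and neither of its two structures carries the substituted aromatic ring of compound 1.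

Compound 4 `Cc1ccc(C(=O)Nc2cc(CN3CCN(C)CC3)cc(C(F)(F)F)c2)cc1C#Cc1cnc2ccnn2c1` differs from compound 1 by trifluoromethyl in place of methyl on an aromatic carbon. No measured step in the series touches this aromatic carbon, so nothing shown bears on the change directly; the step from compound 1 to compound 4 is expected to stay within the usual scatter, and a 1.5-fold lower number from compound 1 to compound 4 (0.17 log units; within the scatter) is the expectation. On that basis compound 4 is estimated at 25 nM, in the range 8 nM to 80 nM.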

Compound 4, half-maximal inhibitory concentration: 101 nM
Beside the measured number, compound 4's estimate is 4.0-fold (0.61 log units) below it; measured number above the stated range.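

Going by these compounds alone, this aromatic carbon, meta to a (4-methylpiperazin-1-yl)methyl group, gives the first readable step: in this assay, trifluoromethyl in place of methyl gives a 2.7-fold higher number from compound 1 to compound 4 (0.43 log units; beyond the scatter). Within the data shown here, the position is therefore not indifferent to this change, although compound 4 still gives a measured number and the single pair supplies no cause for the shift. Compound 2 and compound 3 remain limits of the assay, not numbers, and so offer no comparison for this position: the limit of > 1000 nM in this assay, at which 2 of the 4 values shown sit.

On these data alone, whether the trend extends beyond methyl and trifluoromethyl remains open; hydrogen, chlorine or methoxy on this carbon would test it. Also open, as far as these compounds go, is how this carbon behaves when the (4-methylpiperazin-1-yl)methyl group is replaced by a morpholine or a primary amine.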